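Swapping fluoro for phenyl on a cytotoxic amide

The source may report more compounds than this note shows. Statements on the series, on what has been measured and on what is new or still open speak of the compounds shown alone.

Compound 1 `O=C(Nc1cc(C(F)(F)F)cc(C(F)(F)F)c1)c1cc(Cl)c(F)cc1O`: 470 nM
Compound 2 `O=C(Nc1ccc([N+](=O)[O-])cc1)c1cc(F)ccc1O`: 1100 nM
Compound 3 `N#Cc1ccc(Nc2n[nH]c3ccccc23)cc1`: > 10000 nM

In a functional assay on KG-1 cells (Homo sapiens) for cytotoxicity, read by luminescence and CellTiter-Glo, with a stated time of 3 days (a higher number here means a weaker inhibitor, a lower number a stronger inhibitor), compound 1 gives 470 nM, the lowest of the two true numbers. Compound 2 gives 1100 nM, and that gap lies beyond the usual scatter of repeat measurements. Compound 3 reads > 10000 nM, which is a limit and not a number.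

The next compound to be tested is compound 4 `O=C(Nc1cc(C(F)(F)F)cc(C(F)(F)F)c1)c1cc(Cl)c(-c2ccccc2)cc1O`. It keeps the core of compound 1 but carries phenyl in place of fluoro on an aromatic carbon, ortho to a chloro group, meta to a hydroxy group and para to a large group: phenyl in place of fluoro on an aromatic carbon.

Going by the values given here, no two measured compounds differ in just one place, so the data offer no direct guide to this swap. In this assay no clear shift in either direction is expected. The estimated 1.2-fold higher number from compound 1 to compound 4 (0.07 log units; within the scatter) should stay within the scatter, though with real uncertainty. For compound 4 the expected value is 550 nM, with an estimated range from 150 nM to 2000 nM.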

Compound 4, half-maximal inhibitory concentration: 430 nM
Compound 4: the middle estimate sits 1.3-fold (0.11 log units) above what was measured; the range from low to high includes it.
By their numbers in this assay, from the lowest: compounds 4 and 1 (each within the scatter of the next); then compound 2. At a limit, above all of these: compound 3.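

In this assay, phenyl in place of fluoro gives a 1.1-fold lower number from compound 1 to compound 4 (0.04 log units; within the scatter), so the two compounds read alike even though a single fluorine gives way to a ring of six heavy atoms. The earlier compounds shown here could not show this, since no two of them differed in just one place and this aromatic carbon, ortho to a chloro group and para to a large group, had not been tested on its own. Nothing measured here explains why so large a swap leaves the two numbers within the scatter of each other.

Fluoro and phenyl are the only groups shown at this carbon, so one step cannot reveal how far this tolerance extends. An amine, a carboxylic acid or a longer alkyl chain at the same place remains an open question.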